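A few compounds are considered here, and "the series" means these few. Any claim that something is new, unique, unknown or untested is made for them only; others in the source may bear on it.

Working notes on the series. In an ADME assay on HaCaT cells (Homo sapiens) for cytotoxicity, read by MTT assay, with a stated time of 48 h (on this read-out lower numbers stand for stronger inhibition and higher numbers for weaker inhibition), compound 1 `Cc1ccc2[nH]c(-c3cn(-c4ccccc4)nc3-c3ccccc3)nc2c1` gives > 50000 nM, which is a limit of the assay and not a number. Compound 2 `COc1ccc2[nH]c(-c3cn(-c4ccccc4)nc3-c3ccc(F)cc3)nc2c1` gives > 50000 nM, also a limit and not a number. The whole measured picture so far is the limit of > 50000 nM in this assay, at which 2 of the 2 values shown sit, so the position of compound 2 is known only as a limit.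

Compound 3 `Cc1ccc2[nH]c(-c3cn(-c4ccccc4)nc3-c3ccc(F)cc3)nc2c1` has methyl in place of methoxy on an aromatic carbon of the shared core: methyl in place of methoxy on an aromatic carbon. For the measured compounds named here, no step between measured compounds is available to size this change. In this assay, no step beyond the usual scatter is expected, and this expectation rests on the limit of compound 2 at > 50000 nM. The estimated step is a step that the limit leaves unreadable from compound 2 to compound 3. Compound 3 is expected at 60000 nM, with an estimated range of 30000 nM to 100000 nM, and most likely it will again be reported only as a limit.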

Compound 3, half-maximal inhibitory concentration: > 50000 nM
Compound 3: a limit, no number; the forecaster's own chance of this, stated with the estimate: 85%; the middle value is on the limit's open side.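

No new step can be read among compound 1, compound 2 and compound 3 in this assay, because all their values are limits and not numbers: the limit of > 50000 nM in this assay, at which 3 of the 3 values shown sit.

The compounds shown leave open how large the steps for methyl in place of methoxy and fluoro in place of hydrogen are, and whether any change to the shared core gives a number rather than a limit.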